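A Third Methoxy Group and Its Expected Effect on Toxicity

The compounds below may be only part of what the source reports. "The series", "measured", "known", "first", "only" and "open" are said of these compounds alone.

compound 1, `COc1ccc(-c2cc(/C=C/C(=O)c3ccc(N)cc3)[nH]n2)cc1`: 44300 nM
compound 2, `COc1ccc(C(=O)/C=C/c2cc(-c3cc(OC)c(OC)c(OC)c3)n[nH]2)cc1OC`: 6360 nM
compound 3, `COc1ccc(-c2cc(/C=C/C(=O)c3ccc(N)cc3)[nH]n2)cc1OC`: 46100 nM

All three values come from a functional assay on SNB-19 cells (Homo sapiens) for inhibition, read by sulforhodamine B assay, with a stated time of 48 h; on this read-out lower numbers stand for higher toxicity in this test and higher numbers for lower toxicity in this test. Compound 1 and compound 3 share one core and differ in one place: methoxy in place of hydrogen on an aromatic carbon. That change produced a 1.0-fold higher number from compound 1 to compound 3 (0.02 log units; within the scatter), so the two compounds cannot be told apart on this read-out. Compound 2 is built on a different core, and the difference between the two cores is not broken down here. Compound 2 gives the lowest number of the three, and its distance from compound 1 and from compound 3 lies beyond the scatter, so among the measured compounds it is the most toxic in this assay.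

Compound 4, `COc1cc(C(=O)/C=C/c2cc(-c3cc(OC)c(OC)c(OC)c3)n[nH]2)cc(OC)c1OC`, has not been measured. It differs from compound 2 in one place: methoxy in place of hydrogen on an aromatic carbon. Compared with the change from compound 1 to compound 3, the surroundings differ slightly: in compound 4 the new group is also meta to a methoxy group, whereas in compound 3 it is not. The change is therefore the same kind of change rather than the same change.

The step from compound 2 to compound 4 is expected to be a 1.1-fold higher number from compound 2 to compound 4 (0.04 log units; within the scatter), because the earlier step of this kind gave a 1.0-fold higher number from compound 1 to compound 3 (0.02 log units; within the scatter). Compound 4 is estimated at 7000 nM in this assay. The expected range for compound 4 runs from 2500 nM to 20000 nM.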

Compound 4, concentration lethal to 50% of the cells: 8200 nM
The estimate for compound 4 lay 1.2-fold (0.07 log units) below the measured number; the measured number falls inside the stated range.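

In this assay, putting methoxy in place of hydrogen on an aromatic carbon gave a 1.3-fold higher number from compound 2 to compound 4 (0.11 log units; within the scatter), a step too small to tell this pair apart on this read-out. Set beside the same change on the other core, the result looks alike, and the two steps cannot be told apart from each other: the same change on two cores in this assay, a 1.0-fold higher number (0.02 log units; within the scatter) from compound 1 to compound 3 and a 1.3-fold higher number (0.11 log units; within the scatter) from compound 2 to compound 4, 1.2-fold (0.09 log units) apart, within the scatter of two such steps. For the compounds shown here, this shows that, in these two pairs, the added methoxy group made no readable difference to toxicity in this test on either core, but two small steps are only two examples and do not amount to a rule for the whole series, nor do they show that methoxy would be equally silent on another core or on another ring carbon.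

The compounds shown leave open whether a different group on this aromatic carbon, such as a carboxylic acid or a longer chain like ethoxy, would move the number beyond the scatter. They also leave open whether the same lack of a readable step would hold in other cell types or after another exposure time, since all of these values come from a single test.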